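The compounds below may be only part of what the source reports. "The series", "measured", "known", "first", "only" and "open" are said of these compounds alone.

Measured compounds:
Compound 1 `CCC(/C=C(\COC(=O)c1ccccc1)C(=O)c1ccc(OC)cc1)CC` gives 26800 nM in a functional assay on NB-4 cells (Homo sapiens) for inhibition, read by XTT assay, with a stated time of 48 h; a higher number here means a weaker inhibitor, a lower number a stronger inhibitor.
Compound 2 `COc1ccc(C(=O)/C(=C/c2ccccc2F)CCOC(C)=O)cc1` gives > 100000 nM in this assay, which is a limit of the assay and not a number.

Compound 2 thus stands at the limit of > 100000 nM in this assay, at which 1 of the 2 values shown sits. Compound 3 `CCC(/C=C(\CCOC(C)=O)C(=O)c1ccc(OC)cc1)CC` differs from compound 2 by pentan-3-yl in place of 2-fluorophenyl on a double-bonded chain carbon bound to a double-bonded chain carbon. Among the compounds with values here, no measured step covers this change, so the expectation rests on compound 1, which carries the same pentan-3-yl group and gives 26800 nM. The step from compound 2 to compound 3 is expected to go toward stronger inhibition, estimated as an at least 2.0-fold lower number from compound 2 to compound 3 (0.30 log units; that floor lies within the scatter). Compound 3 is expected to give about 50000 nM in this assay, within 15000 nM to 150000 nM.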

Compound 3, half-maximal inhibitory concentration: 91100 nM
Compound 3: the middle estimate sits 1.8-fold (0.26 log units) below what was measured; low and high end bracket the measured number.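

Putting pentan-3-yl in place of 2-fluorophenyl gives an at least 1.0-fold lower number from compound 2 to compound 3 (0.04 log units; that floor lies within the scatter), a floor only, so this position tolerates the swap without showing how large its effect is. Compound 2 stands at a limit and not at a number: the limit of > 100000 nM in this assay, at which 1 of the 3 values shown sits. With pentan-3-yl held fixed, acetoxymethyl in place of benzoyloxy gives a 3.4-fold higher number from compound 1 to compound 3 (0.53 log units; beyond the scatter), so the ester side chain also moves the number on this background. From the compounds shown here alone, whether an amine or a longer chain at the pentan-3-yl position would shift the number stays open. So does how a benzoyloxy ester would behave with 2-fluorophenyl in place.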